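Swapping the aryl on the double-bonded nitrogen

The compounds below may be only part of what the source reports. "The series", "measured", "known", "first", "only" and "open" are said of these compounds alone.

Compound 1, `CC(=O)/C(=N\c1ccccc1Cl)NNc1ccccc1Cl`: in an assay on isolated protein for binding affinity to corticotropin-releasing factor receptor 1 (Homo sapiens) (on this read-out higher numbers stand for weaker inhibition and lower numbers for stronger inhibition), compound 1 gives > 10000 nM, which is a limit of the assay, not a number.
Compound 2, `COc1cccc(N/C(=N/Nc2ccccc2Cl)C(C)=O)c1`: compound 2 gives 652 nM.
Compound 3, `CC(=O)/C(=N\c1ccccc1Cl)NNc1ccccc1C(F)(F)F`: compound 3 gives > 10000 nM, again a limit rather than a number.

Compound 3 therefore stands at the limit of > 10000 nM in this assay, at which 2 of the 3 values shown sit; nothing more than that limit is known of it. Within the data shown here, the one measured step, a step that the two limits leave unreadable from compound 1 to compound 3, runs between two limits and yields no size. The change now followed is 3-cyanophenyl in place of 2-chlorophenyl on a double-bonded nitrogen, giving compound 4, `CC(=O)/C(=N\c1cccc(C#N)c1)NNc1ccccc1C(F)(F)F`. Among the measured compounds shown here, no measured step covers this change directly. Compound 2 carries a 3-methoxyphenyl on the double-bonded nitrogen and reaches 652 nM. Compound 1, with a 2-chlorophenyl on that nitrogen, remains at the limit. These two values show that exchanging the aryl on the double-bonded nitrogen can bring a compound of this core into the measurable range, though compound 2 also differs from compound 4 in the group on the other side of the core. For compound 4 a step toward stronger binding, an at least 4.0-fold lower number from compound 3 to compound 4 (0.60 log units; beyond the scatter), is expected, with a size that the present numbers cannot fix. Compound 4 is estimated at 2500 nM, between 500 nM and 10000 nM.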

Compound 4, inhibition constant: > 10000 nM
Compound 4 ended at the assay's limit (the forecaster's own chance of this, stated with the estimate: 40%); middle value at least 4.0-fold (0.60 log units) away from the limit.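

Compound 4 sits at the same limit of the assay as compound 3, and a limit is not a number: the limit of > 10000 nM in this assay, at which 3 of the 4 values shown sit. With a limit at both ends, the step from compound 3 to compound 4 cannot be read. Still open, from the compounds shown here alone, is whether 3-cyanophenyl in place of 2-chlorophenyl on the double-bonded nitrogen changes binding at all.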